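A New Group on the Carbonyl Carbon

The compounds below may be only part of what the source reports. "The series", "measured", "known", "first", "only" and "open" are said of these compounds alone.

Within the data shown here, in a functional assay on RT-112 cells (Homo sapiens) for antiproliferative activity, read by MTT assay, with a stated time of 72 h (on this read-out higher numbers stand for weaker inhibition of growth and lower numbers for stronger inhibition of growth), compound 1 (`COc1cc(Nc2ncnc3c(NC(=O)Nc4ccc5c(c4)OCCO5)cccc23)cc(OC)c1`) gives 2750 nM and compound 2 (`COc1cc(Nc2ncnc3c(NC(=O)Nc4ccc(Cl)c(Cl)c4)cccc23)cc(OC)c1`) gives 6230 nM, so compound 2 stands at the higher of the two numbers known, with the weaker inhibition of growth. Among the measured compounds shown here, the only measured step is a 2.3-fold higher number from compound 1 to compound 2 (0.36 log units; beyond the scatter), a modest change that puts 3,4-dichlorophenyl in place of 2,3-dihydro-1,4-benzodioxin-6-yl on an amide-type nitrogen. Compound 3 (`COc1cc(Nc2ncnc3c(NC(=O)c4ccc(CN(C)C)cc4)cccc23)cc(OC)c1`) departs from compound 2 at the same end of the molecule: 4-((dimethylamino)methyl)phenyl in place of (3,4-dichlorophenyl)amino on a carbonyl carbon. For the measured compounds named here, no measured compound carries the entering group, so the step to compound 2, at 6230 nM, offers only a rough guide to size. A modest step towards a lower number is expected, and the estimate is a 2.1-fold lower number from compound 2 to compound 3 (0.32 log units; beyond the scatter). The expected value for compound 3 is 3000 nM, within an estimated range of 900 nM to 10000 nM.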

Compound 3, concentration for 50% growth inhibition: 4370 nM
Compound 3: middle estimate off by 1.5-fold (0.16 log units), on the low side; the range from low to high includes it.
By their numbers in this assay, from the lowest: compounds 1, 3 and 2 (each within the scatter of the next, the first and the last beyond it).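

In this assay the carbonyl carbon takes 4-((dimethylamino)methyl)phenyl in place of (3,4-dichlorophenyl)amino with a 1.4-fold lower number from compound 2 to compound 3 (0.15 log units; within the scatter) and in place of (2,3-dihydro-1,4-benzodioxin-6-yl)amino with a 1.6-fold higher number from compound 1 to compound 3 (0.20 log units; within the scatter) and so neither step separates compound 3 from the compound it is set against. Compounds 1 and 2 both carry an amino group on this carbonyl carbon, whereas compound 3 shows that a phenyl ring can stand there directly and still give a number within the scatter of both. Nothing available here accounts for this result.

From the compounds shown here alone, each step changes the link and the ring's substituents together, so the share of each stays open. A (4-((dimethylamino)methyl)phenyl)amino group would separate the two, and a morpholine or piperazine in place of the dimethylamino group would test whether this particular amine matters.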